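Bromo to chloro in a sulfonamide series

The compounds below may be only part of what the source reports. "The series", "measured", "known", "first", "only" and "open" are said of these compounds alone.

In a functional assay on HT-29 cells (Homo sapiens) for antiproliferative activity, read by sulforhodamine B assay, with a stated time of 48 h (on this read-out higher numbers stand for weaker inhibition and lower numbers for stronger inhibition), compound 1 (`Cc1cccc(NS(=O)(=O)c2ccc(N3CCNC3=O)cc2)c1`) gives 110 nM, compound 2 (`O=C1NCCN1c1ccc(S(=O)(=O)Nc2ccc(F)cc2)cc1`) gives 370 nM and compound 3 (`O=C1NCCN1c1ccc(S(=O)(=O)Nc2cccc(Br)c2)cc1`) gives 77 nM. Compound 3 therefore sits at the low end of these numbers, but it does not stand there alone. The data show a 1.4-fold lower number from compound 1 to compound 3 (0.15 log units; within the scatter), which cannot be told apart from repeat variation, whereas a 4.8-fold lower number from compound 2 to compound 3 (0.68 log units; beyond the scatter) is a real separation.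

Compound 4 (`O=C1NCCN1c1ccc(S(=O)(=O)Nc2cccc(Cl)c2)cc1`) carries chloro in place of bromo on an aromatic carbon, meta to a large group: chloro in place of bromo on an aromatic carbon. Among the measured compounds shown here, no measured compound yet carries chloro, so the step has no direct precedent. The closest guide is bromo in place of methyl on an aromatic carbon, the step already seen between the two low values, which stayed within the scatter. The larger steps, a 3.4-fold higher number from compound 1 to compound 2 (0.53 log units; beyond the scatter) and a 4.8-fold lower number from compound 2 to compound 3 (0.68 log units; beyond the scatter), both involve 4-fluorophenyl, a group absent from this change, and they bear on it only weakly.

No step beyond the scatter is therefore expected in this assay. The expected change is a 1.2-fold higher number from compound 3 to compound 4 (0.07 log units; within the scatter). For compound 4 the estimated value is 90 nM, with an expected range of 40 nM to 200 nM.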

Compound 4, half-maximal inhibitory concentration: 55 nM
For compound 4 the middle estimate is 1.6-fold (0.21 log units) above the measured one; low and high end bracket the measured number.
By their numbers in this assay, from the lowest: compounds 4, 3 and 1 (each within the scatter of the next); then compound 2.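

In this assay, chloro in place of bromo on this aromatic carbon, meta to a large group, gives a 1.4-fold lower number from compound 3 to compound 4 (0.15 log units; within the scatter), so at this position the two halogens cannot be told apart on this read-out. Chloro in place of methyl gives a 2.0-fold lower number from compound 1 to compound 4 (0.30 log units; within the scatter), which also stays within the scatter, so methyl, bromo and chloro now form a set of three groups at this position with no separation among any pair of them, while the clear contrast remains with the 4-fluorophenyl group, where 3-chlorophenyl in its place gives a 6.7-fold lower number from compound 2 to compound 4 (0.83 log units; beyond the scatter). Nothing available gives a reason for these numbers, for the closeness of the three groups or for the distance of compound 2 from them.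

Compound 2 differs from the other three compounds in both the halogen and the place it occupies, so the compounds shown do not tell which of the two goes with its separate position in this assay. It also remains open how an amine, a carboxylic acid or a methoxy group would read on this aromatic carbon, as all three groups shown here give numbers within the scatter of one another.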